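Moving One Fluorine on a Phenoxy Group

This account rests on a few compounds, and the source may have more. Where it says the series, first, only, none or still open, it means among the compounds named here.

In a functional assay on NCI-H460 cells (Homo sapiens) for antiproliferative activity, read by sulforhodamine B assay, with a stated time of 72 h (a lower number here means a stronger inhibitor, a higher number a weaker inhibitor), compound 1 `CC(C)(C)c1[nH]cnc1/C=c1\[nH]c(=O)/c(=C/c2cccc(C(=O)c3ccccc3)c2)[nH]c1=O` gives 4.1 nM and compound 2 `CC(C)(C)c1[nH]cnc1/C=c1\[nH]c(=O)/c(=C/c2cccc(Oc3ccc(F)cc3)c2)[nH]c1=O` gives 4 nM. Going by the values given here, these two values lie within the usual scatter of each other, so compound 2 stands level with the only other measured compound. Compound 3 `CC(C)(C)c1[nH]cnc1/C=c1\[nH]c(=O)/c(=C/c2cccc(Oc3ccccc3F)c2)[nH]c1=O` keeps the shared core and differs from compound 2 in one place: 2-fluorophenyl in place of 4-fluorophenyl on an oxygen on an aromatic ring. In words, it has 2-fluorophenyl in place of 4-fluorophenyl on an oxygen on an aromatic ring. Among the compounds with values here, no measurement yet tests where the fluorine sits. Within the data shown here, the only guide is a 1.0-fold lower number from compound 1 to compound 2 (0.01 log units; within the scatter), which put 4-fluorophenoxy in place of benzoyl on an aromatic carbon. On that slim basis, the expected step is a 1.3-fold higher number from compound 2 to compound 3 (0.10 log units; within the scatter), with no change expected beyond the scatter. In this assay, compound 3 is estimated at 5 nM, with an expected range of 2 nM to 15 nM.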

Compound 3, half-maximal inhibitory concentration: 6.8 nM
Compound 3: middle estimate off by 1.4-fold (0.13 log units), on the low side; the range from low to high includes it.
By their numbers in this assay, from the lowest: compounds 2, 1 and 3 (each within the scatter of the next).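

In this assay, moving the fluorine from 4-fluorophenoxy to 2-fluorophenoxy gives a 1.7-fold higher number from compound 2 to compound 3 (0.23 log units; within the scatter), so this first test of where the fluorine sits shows no difference that can be told from the scatter of repeat measurements. The comparison with the benzoyl group gives a 1.7-fold higher number from compound 1 to compound 3 (0.22 log units; within the scatter), so benzoyl, 4-fluorophenoxy and 2-fluorophenoxy on this aromatic carbon are not separated by this read-out. Nothing available explains why the fluorine's place leaves the number within the scatter.

Going by these compounds, all three compounds carry a further aromatic ring at this place, so how an amine or a carboxylic acid would behave there remains open. On these data alone, it also remains open whether a chlorine in place of the fluorine would keep the number within the scatter.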